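A few compounds are considered here, and "the series" means these few. Any claim that something is new, unique, unknown or untested is made for them only; others in the source may bear on it.

Measured compounds:
Compound 1 `Cc1ncccc1-c1cnc(NCc2c(F)cc(Cl)c3c2CCO3)n2cnnc12` gives 9 uL/min in an ADME assay on cells (Hepatocyte, Rattus norvegicus) for metabolic stability; on this read-out higher numbers stand for fast clearance and lower numbers for slow clearance.
Compound 2 `Cc1cc(F)c(CNc2ncc(-c3cccnc3C)c3nncn23)c2c1OCC2` is recorded as "not determined" (no result reported) in this assay.
Compound 3 `Cc1ncccc1-c1cnc(NCc2c(F)cc(O)c3c2CCO3)n2cnnc12` gives 50 uL/min in this assay.

Of the two compounds with a number, compound 3 stands at the higher end: the step of a 5.6-fold higher number from compound 1 to compound 3 (0.74 log units; beyond the scatter) lies beyond the scatter, so compound 3 is cleared faster than compound 1. The change in question moves from compound 3 to compound 4 `Cc1ncccc1-c1cnc(NCc2c(F)cc(C#N)c3c2CCO3)n2cnnc12`, and it is cyano in place of hydroxy on an aromatic carbon. Going by the values given here, the group that leaves is the same hydroxy group that entered in the step from compound 1 to compound 3, on the same aromatic carbon, so that step is the one piece of evidence that bears on the present change, and it was modest. Compound 4 carries neither hydroxy nor chloro at that place but a cyano group; nothing measured here shows a cyano group directly, so the guidance is indirect. Since the hydroxy group that raised clearance in compound 3 is removed, the number for compound 4 is expected to fall back toward that of compound 1, though a cyano group need not behave like chloro, so the expected step of a 3.3-fold lower number from compound 3 to compound 4 (0.52 log units; beyond the scatter) is taken as a lowering of roughly the size seen before. The estimate for compound 4 is therefore 15 uL/min, with a range from 5 uL/min to 45 uL/min.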

Compound 4, intrinsic clearance in a liver preparation (reported as CLH), per the amount of preparation that the assay uses: 10 uL/min
Estimate against measurement, compound 4: 1.5-fold (0.18 log units) above, and the stated range covers the measured number.
By their numbers in this assay, from the lowest: compounds 1 and 4 (each within the scatter of the next); then compound 3.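

In this assay, putting cyano in place of hydroxy on this aromatic carbon gives a 5.0-fold lower number from compound 3 to compound 4 (0.70 log units; beyond the scatter) and so takes away the raised clearance of compound 3, which until now had only been set against chloro. Putting cyano in place of chloro gives a 1.1-fold higher number from compound 1 to compound 4 (0.05 log units; within the scatter), so two quite different groups, one a single halogen atom and the other a two-atom group with a triple bond, leave the number in the same range, and among the three groups seen at this position hydroxy alone stands apart from the other two. The data shown offer no explanation of why hydroxy differs here.

Going by these compounds alone, with only three groups at this position, it remains open whether chloro and cyano mark a general level for groups without a hydrogen-bond donor or simply happen to match, and whether an amine, a carboxylic acid or a methoxy group would fall with them or with hydroxy. Within the data shown here, it also remains open whether the same gap would appear on any core other than the one shared by these compounds.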